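Permeability notes: aryl for cycloalkylmethyl on the shared core

The source may report more compounds than this note shows. Statements on the series, on what has been measured and on what is new or still open speak of the compounds shown alone.

Compound 3 `COc1ccc(F)cc1CNCCCNc1ccnc2cc(CC3CCCCC3)ccc12` gives 23 10^-6 cm/s in an ADME assay for permeability, using PAMPA, with a stated time of 30 min, at pH 7.4; on this read-out lower numbers stand for lower permeability and higher numbers for higher permeability. It stands level with compound 1 `COc1ccc(F)cc1CNCCCNc1ccnc2cc(CCC(C)C)ccc12`, which gives 23 10^-6 cm/s, the two together being the lowest of the three numbers, with no change at the digits printed from compound 1 to compound 3 (within the scatter). Compound 2 `COc1ccc(F)cc1CNCCCNc1ccnc2cc(-c3ccc(F)cc3)ccc12` gives 237 10^-6 cm/s and sits furthest from compound 3, with a 10-fold lower number from compound 2 to compound 3 (1.01 log units; beyond the scatter).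

The step to compound 4 `COc1ccc(F)cc1CNCCCNc1ccnc2cc(Oc3ccccc3OC)ccc12` is 2-methoxyphenoxy in place of cyclohexylmethyl on an aromatic carbon. Among the measured compounds shown here, two measured steps bear on it. Replacing a saturated group on this aromatic carbon by one carrying a six-membered aromatic ring gave a 10-fold higher number from compound 1 to compound 2 (1.01 log units; beyond the scatter), and the reverse exchange gave a 10-fold lower number from compound 2 to compound 3 (1.01 log units; beyond the scatter). Compound 4 likewise puts a six-membered aromatic ring of carbon only on that carbon, though the entering group also brings two hydrogen-bond acceptors, for which the three measured compounds give no comparison. A rise beyond the scatter is therefore expected, plausibly somewhat smaller than the step seen for compound 2.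

Compound 4 is estimated at 110 10^-6 cm/s in this assay, within 35 10^-6 cm/s to 300 10^-6 cm/s. This estimate means a step of a 4.8-fold higher number from compound 3 to compound 4 (0.68 log units; beyond the scatter), expected on the strength of a 10-fold lower number from compound 2 to compound 3 (1.01 log units; beyond the scatter).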

Compound 4, apparent permeability: 317 10^-6 cm/s
The estimate for compound 4 lay 2.9-fold (0.46 log units) below the measured number, outside the stated range (above it).
By their numbers in this assay, from the lowest: compounds 1 and 3 (each within the scatter of the next); then compounds 2 and 4 (each within the scatter of the next).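

At this aromatic carbon, a linking oxygen does not remove the gain seen with an aromatic ring: in this assay the 2-methoxyphenoxy group gives a 14-fold higher number from compound 3 to compound 4 (1.14 log units; beyond the scatter) against cyclohexylmethyl and a 14-fold higher number from compound 1 to compound 4 (1.14 log units; beyond the scatter) against isopentyl, so the high numbers are no longer tied to the directly attached 4-fluorophenyl group alone. Against that group the reading is a 1.3-fold higher number from compound 2 to compound 4 (0.13 log units; within the scatter) and so the two aromatic groups cannot be told apart here, despite the oxygen link, the methoxy group and the hydrogen-bond acceptors that the 2-methoxyphenoxy group brings; across the four compounds, compounds 2 and 4 with a six-membered aromatic ring in this place stand beyond the scatter from compounds 1 and 3 with saturated groups, and no compound shown goes against this. No measurement at hand accounts for these steps.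

Open, as far as these compounds go, is whether the aromatic ring itself carries the difference, since a cyclohexyloxy group would pair a saturated ring with the same oxygen link and a plain phenoxy group would show the ring without its methoxy group. Also open, from the compounds shown here alone, is how an amine or a carboxylic acid would read on this aromatic carbon of the shared core.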